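Amide variation in a pyrazole-linked dihydroxy acid series

The source may report more compounds than this note shows. Statements on the series, on what has been measured and on what is new or still open speak of the compounds shown alone.

Compound 1 `CC(C)c1c(C(=O)N2CCC[C@H](c3ccccc3)C2)nn(-c2ccc(F)cc2)c1CC[C@@H](O)C[C@@H](O)CC(=O)O` gives 2.1 nM in an assay on microsomes from liver for inhibition of 3-hydroxy-3-methylglutaryl-coenzyme A reductase (Rattus norvegicus) (on this read-out higher numbers stand for weaker inhibition and lower numbers for stronger inhibition), and compound 2 `CC(C)c1c(C(=O)N(C)Cc2cccc(F)c2)nn(-c2ccc(F)cc2)c1CC[C@@H](O)C[C@@H](O)CC(=O)O` gives 4.1 nM. The one-place step between them, a 2.0-fold higher number from compound 1 to compound 2 (0.29 log units; within the scatter), shows that reshaping the amide substituents changed little. Compound 3 `CCN(Cc1ccccc1)C(=O)c1nn(-c2ccc(F)cc2)c(OC[C@@H](O)C[C@@H](O)CC(=O)O)c1C(C)C` gives 14 nM, the highest of the three numbers, beyond the scatter from both compound 2 and compound 1. Compound 4 `Cc1ccccc1CNC(=O)c1nn(-c2ccc(F)cc2)c(OC[C@@H](O)C[C@@H](O)CC(=O)O)c1C(C)C` differs from compound 3 by (2-methylbenzyl)amino in place of benzyl(ethyl)amino on a carbonyl carbon. Among the compounds with values here, the only step that bears on this, from compound 1 to compound 2, was small, so compound 4 is expected to sit near compound 3, with a step of a 1.3-fold higher number from compound 3 to compound 4 (0.11 log units; within the scatter) that may fall within the scatter. Compound 4 is therefore estimated at 18 nM, between 7 nM and 45 nM.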

Compound 4, half-maximal inhibitory concentration: 17 nM
For compound 4 the middle estimate is 1.1-fold (0.02 log units) above the measured one; the range from low to high includes it.
By their numbers in this assay, from the lowest: compounds 1 and 2 (each within the scatter of the next); then compounds 3 and 4 (each within the scatter of the next).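

In this assay the change gives a 1.2-fold higher number from compound 3 to compound 4 (0.08 log units; within the scatter) and so shows that this carbonyl carbon accepts the amide hydrogen, one hydrogen-bond donor where benzyl(ethyl)amino has none, without a change beyond the scatter. The earlier step involved no amide hydrogen on either side, and it concerned a different core. No measurement bearing on why the number holds is available. As far as these compounds go, what stays open is whether a carboxylic acid or an amine on the benzyl ring would also leave the number within the scatter. From the compounds shown here alone, a longer chain between the amide nitrogen and that ring remains equally open.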